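Aryl group change in a cytotoxicity series: working notes

A few compounds are considered here, and "the series" means these few. Any claim that something is new, unique, unknown or untested is made for them only; others in the source may bear on it.

compound 1 `COc1ccc(/C=C\C(=O)O)c(OCc2cn(-c3ccccc3C(=O)N3CCC(O)C3)nn2)c1CC=C(C)C` — 25400 nM
compound 2 `COc1ccc(/C=C\C(=O)O)c(OCc2cn(-c3cccc([N+](=O)[O-])c3)nn2)c1CC=C(C)C` — 6900 nM

In a functional assay on COLO 205 cells (Homo sapiens) for cytotoxicity, read by MTT assay, with a stated time of 24 h (a lower number here means a stronger inhibitor, a higher number a weaker inhibitor), compound 2 holds the lower of the two numbers, and compound 1 sits well above it, a gap that lies beyond the scatter. Compound 3 `COc1ccc(/C=C\C(=O)O)c(OCc2cn(-c3ccc(CO)cc3)nn2)c1CC=C(C)C` has not been measured in this assay. It differs from compound 2 as follows: 4-(hydroxymethyl)phenyl in place of 3-nitrophenyl on an aromatic nitrogen. Going by the values given here, no step between two measured compounds at this position exists, so the size of the change is uncertain. The only other aryl variant measured, compound 1, gives 25400 nM, which leaves room for a move toward higher numbers. The step of a 1.7-fold higher number from compound 2 to compound 3 (0.24 log units; within the scatter) is expected to be modest, toward a weaker inhibitor, near the edge of the scatter. Compound 3 is therefore estimated at 12000 nM, with a range from 4000 nM to 40000 nM.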

Compound 3, half-maximal inhibitory concentration: 19300 nM
The estimate for compound 3 lay 1.6-fold (0.21 log units) below the measured number; low and high end bracket the measured number.
By their numbers in this assay, from the lowest: compound 2; then compounds 3 and 1 (each within the scatter of the next).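

In this assay, going by these compounds alone, the first measured step at this aryl position is a 2.8-fold higher number from compound 2 to compound 3 (0.45 log units; beyond the scatter) and it lies beyond the scatter, so exchanging 3-nitrophenyl for 4-(hydroxymethyl)phenyl on the aromatic nitrogen does change the read-out, toward a weaker inhibitor. Compound 3 at 19300 nM and compound 1 at 25400 nM lie within the scatter of each other, which leaves compound 2 alone apart from the other two aryl variants. Nothing at hand accounts for the step.

The identity of the group and its place on the phenyl ring change together in this step, so their separate shares remain unresolved. From the compounds shown here alone, whether an amine or a carboxylic acid on the phenyl ring would fall nearer compound 2 or compound 3 also remains open.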